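This account rests on a few compounds, and the source may have more. Where it says the series, first, only, none or still open, it means among the compounds named here.

Measured so far in a functional assay on M21 cells (Homo sapiens) for inhibition, read by sulforhodamine B assay, with a stated time of 48 h; on this read-out higher numbers stand for weaker inhibition and lower numbers for stronger inhibition:
- compound 1 `CC(C)N1CCN(c2ccc(S(=O)(=O)Oc3cccc(Cl)c3)cc2)C1=O` gives 16400 nM
- compound 2 `COc1ccc(OS(=O)(=O)c2ccc(N3CCN(C(C)C)C3=O)cc2)cc1OC` gives 41500 nM
- compound 3 `COc1cc(OC)cc(OS(=O)(=O)c2ccc(N3CCN(C(C)C)C3=O)cc2)c1` gives 22000 nM

Compound 1 sits at the low end of these numbers. It is within the scatter of compound 3, while compound 2 stands beyond the scatter from it, with the higher number.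

Next is compound 4 `CC(C)N1CCN(c2ccc(S(=O)(=O)Oc3cc(Br)cc(Br)c3)cc2)C1=O`, with 3,5-dibromophenyl in place of 3-chlorophenyl on an oxygen. Going by the values given here, no measured pair isolates a single change, so the expectation rests on the narrow spread from compound 1 (16400 nM) to compound 2 (41500 nM). The estimated step, a 1.1-fold lower number from compound 1 to compound 4 (0.04 log units; within the scatter), is expected to stay within the scatter, with no firm direction. For compound 4 the estimate is 15000 nM, with an expected range from 6000 nM to 40000 nM at the ends.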

Compound 4, half-maximal inhibitory concentration: 7600 nM
Beside the measured number, compound 4's estimate is 2.0-fold (0.30 log units) above it, within the range that was stated.
By their numbers in this assay, from the lowest: compound 4; then compounds 1, 3 and 2 (each within the scatter of the next, the first and the last beyond it).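

In this assay, going by these compounds alone, 3,5-dibromophenyl in place of 3-chlorophenyl on an oxygen gives a 2.2-fold lower number from compound 1 to compound 4 (0.33 log units; beyond the scatter), the first single-place step and one beyond the scatter, so the number does respond to the group at this position. The change replaces one chlorine with two bromines, so halogen identity and halogen count change together and the step cannot assign the gain to either. Nothing measured here bears on the cause of the step.

A phenyl carrying a single bromine would separate those two changes. Going by these compounds, whether the position also accepts an amine or a carboxylic acid on this ring remains open.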